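Chloro addition on the benzyl ring of two cores

The compounds below may be only part of what the source reports. "The series", "measured", "known", "first", "only" and "open" are said of these compounds alone.

Compound 1 `Cn1c(=O)[nH]c2ccc(OCc3ccc(Cl)cc3)cc21` and compound 2 `Cn1c(=O)[nH]c2ccc(OCc3ccc(Cl)c(Cl)c3)cc21` share one core; compound 3 `CC1(C)C(=O)Nc2ccc(OCc3cccc(Cl)c3)cc21` and compound 4 `CC1(C)C(=O)Nc2ccc(OCc3ccc(Cl)c(Cl)c3)cc21` share another. The difference between the two cores is not broken down here. In an assay on cells for inhibition of Amine oxidase [flavin-containing] B (Homo sapiens), read by fluorescence, with stated times of 30 min and 15 min, tested at 1 uM (on this read-out higher numbers stand for more inhibition at the one concentration tested (going by the name of the read-out) and lower numbers for less inhibition), compound 1 gives 8.29%, and compound 2 gives 32.4%. The change from compound 1 to compound 2 is chloro in place of hydrogen on an aromatic carbon, and it made a step of a number 24.1 percentage points higher from compound 1 to compound 2 (beyond the scatter). Compound 3 gives 21.1% in this assay, standing second of the three measured numbers.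

The change from compound 3 to compound 4 is chloro in place of hydrogen on an aromatic carbon. It is the same kind of change as from compound 1 to compound 2, though not the same: in the earlier pair the entering chloro sits meta to a large group, here it sits para to a large group. Only one measured occurrence of this change exists, so the expectation for compound 4 rests on it alone. A step of about a number 20.9 percentage points higher from compound 3 to compound 4 (beyond the scatter) is expected from compound 3 to compound 4 in this assay, beside the earlier one, because of a number 24.1 percentage points higher from compound 1 to compound 2 (beyond the scatter). Compound 4 is estimated at 42% in this assay, with an expected range from 25% to 60%.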

Compound 4, a percentage reported as inhibition, at one concentration (the size of the read-out at that concentration, not a potency): 28.8%
For compound 4 the middle estimate is 13.2 percentage points above the measured one, within the range that was stated.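

In this assay the chloro change does not carry over in size from one core to the other, as a number 7.7 percentage points higher from compound 3 to compound 4 (within the scatter) stands against the earlier step: the same change on two cores in this assay, a number 24.1 percentage points higher (beyond the scatter) from compound 1 to compound 2 and a number 7.7 percentage points higher (within the scatter) from compound 3 to compound 4, 16.4 percentage points apart, beyond the scatter of two such steps

The step seen on the core of compound 1 therefore cannot be treated as a fixed increment for this series: on the core of compound 3, the entering chloro, para to a large group and ortho to a chloro group, gives no step beyond the scatter. What is not shown is whether the core or the place of the entering chloro accounts for the gap, as the two pairs differ in both and the data do not separate them.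

Open, from the compounds shown here alone, is how other groups at this place on the benzyl ring, such as a nitrile, a methoxy group or an amine, would read in this assay on either core. Also open, going by these compounds, is how these readings at one concentration relate to potency across the series.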